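A few compounds are considered here, and "the series" means these few. Any claim that something is new, unique, unknown or untested is made for them only; others in the source may bear on it.

Compound 1 `CN(C)CCC(OC(=O)c1ccc(-c2ccccc2)cc1)c1ccc(Cl)cc1` gives 525 nM in an assay on NIH3T3 cells with Urotensin-2 receptor (Homo sapiens) as the target (a higher number here means that more compound is needed for the effect, a lower number that less compound is needed), and stands second highest among the three measured numbers. Compound 3 `Cc1cc(C)c(C(=O)OC(CCN(C)C)c2ccc(Cl)cc2)cc1C` gives 468 nM, within the scatter of compound 1, while compound 2 `CN(C)CCC(OC(=O)c1ccc2ccccc2c1)c1ccc(Cl)cc1` gives 2090 nM, a higher number beyond the scatter. Compound 4 `Cc1ccc(C(=O)OC(CCN(C)C)c2ccc(Cl)cc2)cc1` differs from compound 1 by methyl in place of phenyl on an aromatic carbon. Because compound 3, which also carries methyl groups, gives 468 nM close to the number for compound 1, only a small step is expected from this change. The step from compound 1 to compound 4 is expected to be a 1.3-fold higher number from compound 1 to compound 4 (0.12 log units; within the scatter), a slight rise or none beyond the scatter. Compound 4 is therefore estimated at 700 nM, with a range from 300 nM to 1600 nM.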

Compound 4, half-maximal effective concentration: 2750 nM
Compound 4: middle estimate off by 3.9-fold (0.59 log units), on the low side; the measured number lies above the stated range.
By their numbers in this assay, from the lowest: compounds 3 and 1 (each within the scatter of the next); then compounds 2 and 4 (each within the scatter of the next).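

In this assay, among the compounds shown here, methyl in place of phenyl on an aromatic carbon, para to a large group, gives a 5.2-fold higher number from compound 1 to compound 4 (0.72 log units; beyond the scatter), the first step here that changes only one place. This shows that the number at this position depends on the group it carries, and that cutting the phenyl down to methyl does not leave it within the scatter. Nothing measured here explains the step. The compounds shown leave open what an ethyl, a cyclohexyl or a pyridyl group would give at this position. They also leave open whether an amine or a carboxylic acid would be tolerated there.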